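A Smaller Alkyl Group and an Expected Loss of Binding

The source may hold more compounds than are shown below. What is called first, only, known or untested is meant among the compounds shown, and "the series" means these compounds.

Of the compounds shown here, three have been measured in an assay on membranes from heart (Canis lupus familiaris) for displacement of a labelled ligand from sulfonylurea receptor 2, Kir6.2 (Homo sapiens); a higher number here means a weaker inhibitor, a lower number a stronger inhibitor. Compound 1 `CC(/N=C(\NC#N)Nc1cccc(C#N)c1)C(C)(C)C` gives 350 nM. Compound 2 `CCC(C)(C)/N=C(\NC#N)Nc1ccc(I)c(N=[N+]=[N-])c1` gives 57 nM. Compound 3 `CC(C)/N=C(\NC#N)Nc1ccc(C#N)cc1` gives 7300 nM, the highest number of the three: it lies beyond the scatter above compound 1 and further still above compound 2, so compound 3 is the weakest inhibitor of this set. Compound 4 `C/N=C(\NC#N)Nc1ccc(C#N)cc1` has not yet been measured. It differs from compound 3 in one place: methyl in place of isopropyl on a double-bonded nitrogen. The measured compounds also differ from one another in other parts of the structure, so no clean comparison of the alkyl group alone is available. Still, compound 3, carrying the smallest alkyl group among the measured compounds, stands at the weak end, and methyl is smaller again. The step of a 2.7-fold higher number from compound 3 to compound 4 (0.44 log units; beyond the scatter) is therefore expected to run upward, toward weaker binding, by a margin beyond the scatter. Compound 4 is expected to give about 20000 nM, within a range from 7000 nM to 60000 nM.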

Compound 4, inhibition constant: > 30000 nM
Compound 4: a limit, no number (the forecaster's own chance of this, stated with the estimate: 20%); middle value at least 1.5-fold (0.17 log units) from the limit.
By their numbers in this assay, from the lowest: compound 2; then compound 1; then compound 3. At a limit, above all of these: compound 4.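

Replacing isopropyl with methyl on a double-bonded nitrogen gives an at least 4.1-fold higher number from compound 3 to compound 4 (0.61 log units; beyond the scatter), the only comparison shown in which the alkyl group is the sole change. In this assay compound 4 gives > 30000 nM, which is a limit of the assay and not a number. From the compounds shown here alone, this pair therefore shows that removing carbon from this alkyl group costs binding beyond the scatter, but the step has only a lower bound and its full size stays unknown: the limit of > 30000 nM in this assay, at which 1 of the 4 values shown sits.

The compounds shown leave open how an ethyl group, which lies in size between methyl and isopropyl, or a longer chain such as hexyl would behave at this nitrogen on the core of compound 3. Compound 1 and compound 2 differ from compound 3 in more than one place, so they cannot settle this.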